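The source may report more compounds than this note shows. Statements on the series, on what has been measured and on what is new or still open speak of the compounds shown alone.

Measured in a functional assay on HCT-15 cells (Homo sapiens) for inhibition, read by sulforhodamine B assay, with a stated time of 48 h; a lower number here means a stronger inhibitor of growth, a higher number a weaker inhibitor of growth:
- compound 1 `Cc1ccc(C2=NN(c3ccc(S(C)(=O)=O)cc3)C(=O)CC2)cc1`: 610 nM
- compound 2 `Cc1cc(O)ccc1C1=NN(c2ccc(S(C)(=O)=O)cc2)C(=O)CC1`: 7910 nM

Of these two values, compound 2 has the higher, and so the weaker growth inhibition (7910 nM). Compound 3 `CCc1ccc(C2=NN(c3ccc(S(C)(=O)=O)cc3)C(=O)CC2)cc1` has not yet been measured. It has 4-ethylphenyl in place of 4-hydroxy-2-methylphenyl on a carbon with a double bond to nitrogen. For the measured compounds named here, one measured step bears on this change, and it is large (a 13-fold higher number from compound 1 to compound 2 (1.11 log units; beyond the scatter)). That step introduced the group that now leaves. The entering 4-ethylphenyl resembles the 4-methylphenyl of compound 1 (610 nM) more than it does the leaving group. A large step to a lower number is therefore expected in this assay, estimated as (an 11-fold lower number from compound 2 to compound 3 (1.05 log units; beyond the scatter)). The estimate for compound 3 is 700 nM (expected range 250 nM to 2000 nM).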

Compound 3, concentration for 50% growth inhibition: 1900 nM
Estimate against measurement, compound 3: 2.7-fold (0.43 log units) below, within the range that was stated.
By their numbers in this assay, from the lowest: compound 1; then compound 3; then compound 2.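

In this assay the 4-ethylphenyl group on the carbon with a double bond to nitrogen gives a clear gain over 4-hydroxy-2-methylphenyl (a 4.2-fold lower number from compound 2 to compound 3 (0.62 log units; beyond the scatter)), yet it does not fully return to the 4-methylphenyl of compound 1. Growth inhibition at this position therefore also responds to a change as small as one added methyl on a saturated chain carbon bound to an aromatic carbon (a 3.1-fold higher number from compound 1 to compound 3 (0.49 log units; beyond the scatter)), and compound 1 remains the strongest of the three. No measurement here accounts for either step.

The compounds shown leave open how a propyl chain, a methoxy group or an amine would behave in place of the ethyl. They also leave open whether the hydroxy group or the extra methyl of 4-hydroxy-2-methylphenyl matters more for the weaker growth inhibition of compound 2.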